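Gem-dimethyl ring contraction on the chloropyridine series

This account rests on a few compounds, and the source may have more. Where it says the series, first, only, none or still open, it means among the compounds named here.

Compound 1 `CC(=O)N[C@@H]1CCC[C@H](C(=O)Nc2cc(-c3cnc4n3CCCC4)c(Cl)cn2)C1` gives 16 mL.min-1.g-1 in an ADME assay on microsomes from liver (Homo sapiens) for metabolic stability (on this read-out higher numbers stand for fast clearance and lower numbers for slow clearance), which sets it as the lowest of the two numbers shown; compound 3 `CC(=O)N[C@@H]1CCC[C@H](C(=O)Nc2cc(-c3cnn4c3CC(C)(C)C4)c(F)cn2)C1` sits nearby at 19 mL.min-1.g-1, a difference within the scatter. Compound 2 `CC(=O)N[C@@H]1CCC[C@H](C(=O)Nc2cc(-c3cnn4c3CC(C)(C)C4)ccn2)C1` gives only a limit of this assay, < 3 mL.min-1.g-1, so its clearance is known just as a limit (the limit of < 3 mL.min-1.g-1 in this assay, at which 1 of the 3 values shown sits). Among the measured compounds shown here, the one measured step that changes a single place, an at least 6.3-fold higher number from compound 2 to compound 3 (0.80 log units; beyond the scatter), concerns a fluoro for hydrogen exchange on the core and not the bicyclic group, so it bears on the present question only indirectly.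

Compound 4 `CC(=O)N[C@@H]1CCC[C@H](C(=O)Nc2cc(-c3cnc4n3CC(C)(C)C4)c(Cl)cn2)C1` differs from compound 1 at the bicyclic group: a group of 10 heavy atoms (8 carbon, 2 nitrogen; one five-membered non-aromatic ring with 1 hetero atom, one five-membered aromatic ring with 2 hetero atoms) in place of a group of 9 heavy atoms (7 carbon, 2 nitrogen; one five-membered aromatic ring with 2 hetero atoms, one six-membered non-aromatic ring with 1 hetero atom), on an aromatic carbon. For the measured compounds named here, no measured pair shows this exact exchange. Compound 3 carries a five-membered non-aromatic ring with two methyl groups on its bicycle and gives a number close to compound 1, so no step beyond the scatter is expected here.

Compound 4 is therefore estimated at 13 mL.min-1.g-1, within 5 mL.min-1.g-1 to 30 mL.min-1.g-1, meaning an expected step of a 1.2-fold lower number from compound 1 to compound 4 (0.09 log units; within the scatter).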

Compound 4, intrinsic clearance in microsomes: 63 mL.min-1.g-1
Estimate against measurement, compound 4: 4.8-fold (0.69 log units) below, outside the stated range (above it).
By their numbers in this assay, from the lowest: compounds 1 and 3 (each within the scatter of the next); then compound 4. At a limit, below all of these: compound 2.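

At this position, on an aromatic carbon ortho to a chloro group, exchanging the six-membered non-aromatic ring of the bicyclic group for the five-membered non-aromatic ring with its two methyl groups is not neutral in this assay: the result is a 3.9-fold higher number from compound 1 to compound 4 (0.60 log units; beyond the scatter). Among the compounds shown here, until now the only single-place step lay on the core, an at least 6.3-fold higher number from compound 2 to compound 3 (0.80 log units; beyond the scatter), so this is the first reading of the bicyclic group on its own, and it points to faster clearance with the new group. Nothing measured here gives a cause for this step.

On these data alone, it remains open whether the step carries over with fluoro or hydrogen in place of the chloro group. Also open, as far as these compounds go, is whether a hydroxyl group in place of the two methyl groups would bring the number back towards that of compound 1.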